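This account rests on a few compounds, and the source may have more. Where it says the series, first, only, none or still open, it means among the compounds named here.

Two ureas built on a shared core have been measured in a functional assay on NCI-H226 cells (Homo sapiens) for inhibition, read by MTT assay, with a stated time of 48 h, tested at 10 uM; on this read-out higher numbers stand for more inhibition at the one concentration tested (going by the name of the read-out) and lower numbers for less inhibition. Compound 1 `COc1cc(NC(=O)Nc2cc(Nc3cc(C)cc(F)c3)ncn2)cc(OC)c1` gives 35.3% in this assay, which is the lower of the two numbers seen so far. Compound 2 `O=C(Nc1cc(Nc2ccc(F)c(Cl)c2)ncn1)Nc1c(Cl)cccc1Cl` gives 47.3% in this assay, a value beyond the scatter above that of compound 1. The two differ in several places at once, so no single change can be read from them.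

Compound 3 `COc1cc(NC(=O)Nc2cc(Nc3cc(F)ccc3OC)ncn2)cc(OC)c1` is not yet measured. It differs from compound 1 in one place: 5-fluoro-2-methoxyphenyl in place of 3-fluoro-5-methylphenyl on a nitrogen on an aromatic ring. Going by the values given here, no measured pair shows this change, so its effect is unknown. In this assay the step of a number 2.7 percentage points higher from compound 1 to compound 3 (within the scatter) is expected to be small and to stay within the scatter, in either direction. Compound 3 is therefore estimated to give 38% in this assay, in a range from 20% to 56%.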

Compound 3, a percentage reported as inhibition, at one concentration (the size of the read-out at that concentration, not a potency): 37.7%
Compound 3: the middle estimate sits 0.3 percentage points above what was measured; the range from low to high includes it.
By their numbers in this assay, from the lowest: compounds 1, 3 and 2 (each within the scatter of the next, the first and the last beyond it).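

In this assay, placing 5-fluoro-2-methoxyphenyl in place of 3-fluoro-5-methylphenyl on a nitrogen on an aromatic ring gives a number 2.4 percentage points higher from compound 1 to compound 3 (within the scatter), so this assay does not tell the two groups apart. Going by these compounds alone, this is the first comparison here that isolates a single change, and it shows that the position can take the group with one more heavy atom and a hydrogen-bond acceptor with no shift beyond the scatter. No supporting data bear on the reason for this result.

On these data alone, how the position would respond to a much different group, such as an amine or a carboxylic acid, remains open. So does the role of the other end of the urea, which compound 1 and compound 3 share.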